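This account rests on a few compounds, and the source may have more. Where it says the series, first, only, none or still open, it means among the compounds named here.

Compound 1 `Cc1cn([C@H]2C[C@H](SSC(Cl)(Cl)Cl)[C@@H](CO)O2)c(=O)[nH]c1=O`, compound 2 `C=CCSS[C@H]1C[C@H](n2cc(C)c(=O)[nH]c2=O)O[C@@H]1CO` and compound 3 `CCCCSS[C@H]1C[C@H](n2cc(C)c(=O)[nH]c2=O)O[C@@H]1CO` share one core and differ only in the group carried on the outer sulfur. In a physicochemical assay for pharmacokinetics, at pH 7.2 (on this read-out higher numbers stand for a longer-lived compound and lower numbers for a shorter-lived compound), compound 1 gives only a limit, < 0.0834 h. In this assay compound 2 likewise reaches only the limit, < 0.0834 h. In this assay compound 3 too stands at the limit, < 0.0834 h. For the measured compounds named here, because of the limit of < 0.0834 h in this assay, at which 3 of the 3 values shown sit, the steps among them, a step that the two limits leave unreadable from compound 1 to compound 2, a step that the two limits leave unreadable from compound 1 to compound 3 and a step that the two limits leave unreadable from compound 2 to compound 3, cannot be sized, so no step carries a readable size. Compound 4 `CCCCCCCCSS[C@H]1C[C@H](n2cc(C)c(=O)[nH]c2=O)O[C@@H]1CO` has not been measured in this assay. It differs from compound 3 by butyl in place of hydrogen on a saturated chain carbon, four bonds along the chain from a sulfur. The measured steps that bear on it, the exchange of the group on the outer sulfur among allyl, butyl and trichloromethyl, all stayed within the same limit. The expected step is therefore a step that the limit leaves unreadable from compound 3 to compound 4, none beyond the scatter. Compound 4 is expected to give 0.05 h, between 0.01 h and 0.2 h, most likely again reported only as a limit.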

Compound 4, half-life: < 0.0834 h
Compound 4 ended at the assay's limit; the forecaster's own chance of this, stated with the estimate: 80%; the middle value does not contradict the limit.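

The steps linking compound 4 to compound 1, compound 2 and compound 3 cannot be read, so no new step emerges, because of this: the limit of < 0.0834 h in this assay, at which 4 of the 4 values shown sit.

The compounds shown leave open how long any of them actually lasts in this assay, and whether the group on the outer sulfur affects the half-life at all.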